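The source may hold more compounds than are shown below. What is called first, only, known or untested is meant among the compounds shown, and "the series" means these compounds.

Working notes on a small series sharing one core and varying the aryl group attached to it. Compound 1 is `CCC1=C(O)c2c(oc(-c3cccc(OC)c3)cc2=O)C(CC)(CC)C1=O`, compound 2 is `CCC1=C(O)c2c(oc(-c3cccc(F)c3)cc2=O)C(CC)(CC)C1=O`, compound 3 is `CCC1=C(O)c2c(oc(-c3ccccc3OC)cc2=O)C(CC)(CC)C1=O`, and compound 4, not yet measured, is `CCC1=C(O)c2c(oc(-c3ccccc3F)cc2=O)C(CC)(CC)C1=O`.

In a functional assay on KB cells (Homo sapiens) for antiproliferative activity, read by sulforhodamine B assay, with a stated time of 3 days (on this read-out lower numbers stand for an effect already at smaller amounts and higher numbers for an effect only at larger amounts of compound), compound 1 gives 13.3 uM. Compound 2 reaches only the limit of this assay, > 56.2 uM, so no number is available for it. Compound 3 gives 40.8 uM in this assay.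

Compound 3 and compound 1 differ in their cores as 2-methoxyphenyl in place of 3-methoxyphenyl on an aromatic carbon, which in this assay gives a 3.1-fold higher number from compound 1 to compound 3 (0.49 log units; beyond the scatter). Between compound 2 and compound 3 the step is an at least 1.3-fold lower number from compound 2 to compound 3 (0.13 log units; that floor lies within the scatter), and only a limit is known for the first of the two; see (the limit of > 56.2 uM in this assay, at which 1 of the 3 values shown sits).

The change from compound 3 to compound 4 is fluoro in place of methoxy on an aromatic carbon. The same change is made from compound 1 to compound 2, (fluoro in place of methoxy on an aromatic carbon), where it gave an at least 4.2-fold higher number from compound 1 to compound 2 (0.62 log units; beyond the scatter). The two places differ: in compound 1 the group sits meta to a large group, in compound 3 ortho to a large group, so the change is the same kind of change and not the same.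

Compound 4 is expected to show a 2.7-fold higher number from compound 3 to compound 4 (0.43 log units; beyond the scatter) in this assay. This expectation rests on the step of an at least 4.2-fold higher number from compound 1 to compound 2 (0.62 log units; beyond the scatter), applied to compound 3, which gives 40.8 uM. Compound 4 is therefore estimated at 110 uM, within 40 uM to 300 uM, most likely reported as a limit.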

Compound 4, concentration for half-maximal effect: > 56.2 uM
Compound 4 was reported as a limit; the forecaster's own chance of this, stated with the estimate: 70%; the middle value lies beyond the limit too.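

In this assay compound 4 gives > 56.2 uM, which is a limit of the assay and not a number. Among the compounds shown here, the step of an at least 1.3-fold higher number from compound 3 to compound 4 (0.13 log units; that floor lies within the scatter) therefore fixes only a floor, the step of an at least 4.2-fold higher number from compound 1 to compound 4 (0.62 log units; beyond the scatter) compares two different aryl groups and not the one change alone, and the step between compound 2 and compound 4 cannot be read. Fluoro in place of methoxy shows no sign of acting differently on the two aryl placements, but neither is it shown to carry over from one to the other with the same size, and a real difference between the two remains possible: the same change on two cores in this assay, an at least 4.2-fold higher number (0.62 log units; beyond the scatter) from compound 1 to compound 2 and an at least 1.3-fold higher number (0.13 log units; that floor lies within the scatter) from compound 3 to compound 4; the limit leaves it open whether they differ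

As far as these compounds go, how far the fluoro compounds lie from the methoxy compounds remains unknown, and the comparison stops at the top of the range of this assay: the limit of > 56.2 uM in this assay, at which 2 of the 4 values shown sit. Also open is whether another group at the same place on the aryl ring, such as an amine, a carboxylic acid or a nitrile, would give a number inside that range and so allow the effect of this position to be measured on both placements.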